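The source may report more compounds than this note shows. Statements on the series, on what has been measured and on what is new or still open speak of the compounds shown alone.

Compound 1 `COc1ccc(C(=O)/C=C/c2ccc(Br)cc2)c2c1C=CC(C)(C)O2` is the starting point of this step. In a functional assay on HT-29 cells (Homo sapiens) for antiproliferative activity, read by MTT assay, with a stated time of 24 h (on this read-out lower numbers stand for stronger inhibition and higher numbers for weaker inhibition), compound 1 gives > 10000 nM, which is a limit of the assay and not a number. Compound 2 `COc1ccc(C(=O)/C=C/c2ccc(N(c3ccccc3)c3ccccc3)cc2)c2c1C=CC(C)(C)O2` shares the same core and also returns only a limit: in this assay compound 2 gives > 10000 nM. Compound 3 `COc1ccc(C(=O)/C=C/c2cccc3ccccc23)c2c1C=CC(C)(C)O2` behaves the same way, giving > 10000 nM in this assay, again a limit. Compound 1 therefore stands at the limit alongside the other two, with no measured number to place it higher or lower than either; this is summed up by the limit of > 10000 nM in this assay, at which 3 of the 3 values shown sit. Within the data shown here, no step between measured compounds can be read out, since none of the three gives a number.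

Compound 4 `COc1ccccc1/C=C/C(=O)c1ccc(OC)c2c1OC(C)(C)C=C2` is the compound still to be measured. It differs from compound 1 in one place: 2-methoxyphenyl in place of 4-bromophenyl on a double-bonded chain carbon bound to a double-bonded chain carbon. Among the measured compounds shown here, nothing measured so far tells in which direction such a change acts on this read-out. For the measured compounds named here, for this assay the expected step is a step that the limit leaves unreadable from compound 1 to compound 4, that is, none beyond the usual scatter, because the limit of > 10000 nM in this assay, at which 3 of the 3 values shown sit, holds for every compound measured so far. Compound 4 is thus expected to give 15000 nM in this assay, within a range from 5000 nM to 50000 nM, and most likely the assay will once more report only a limit.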

Compound 4, half-maximal inhibitory concentration: > 10000 nM
Compound 4 ended at the assay's limit; the forecaster's own chance of this, stated with the estimate: 80%; the middle value lies beyond the limit too.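

In this assay compound 4 gives > 10000 nM as a limit of the assay and not a number. Among these compounds, no step from compound 1 to compound 4 can be read, because both compounds stand at a limit: the limit of > 10000 nM in this assay, at which 4 of the 4 values shown sit. The compounds shown leave open whether any change on the shared core gives a number in this assay and in which direction such a change acts.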